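The source may hold more compounds than are shown below. What is called first, only, known or untested is meant among the compounds shown, and "the series" means these compounds.

Working notes on the series. Of the compounds shown here, two have numbers so far. Compound 1 `COc1cc([C@@H]2O[C@@H](CC(=O)CCc3ccc(O)cc3)[C@@H]3[C@H]2[C@H](CC(=O)CCc2ccc(O)cc2)O[C@H]3c2ccc(O)c(OC)c2)ccc1O` carries two copies of the phenolic side chain on a shared core, and in a functional assay on BV-2 cells (Mus musculus), with stated times of 2 h and 24 h, tested at 10 uM (on this read-out lower numbers stand for a stronger effect and higher numbers for a weaker effect at the one concentration tested), compound 1 gives 85%. Compound 2 `Oc1ccc(CC[C@@H](O)C[C@H](O)CCc2ccc(O)cc2)cc1` is the open-chain diol analogue, and in this assay compound 2 gives 94.8%. On the two numbers shown, compound 2 and compound 1 sit within the usual scatter of each other, so no order between them can be read from these readings; both point to a weak effect at the single concentration tested.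

Compound 3 `COc1cc(CC[C@@H](O)C[C@H](O)CCc2ccc(O)cc2)ccc1O` is the next one to go into this assay. It differs from compound 2 in one place: methoxy in place of hydrogen on an aromatic carbon. Among the measured compounds shown here, no measured pair in this set separates by a change of this kind alone, so there is no reference step to lean on. Given how close compound 2 and compound 1 lie in this assay, the expectation is a step no larger than the scatter, with no direction favoured. The value of compound 3 in this assay is estimated at 90%, in a range from 75% to 103%. This estimate implies an expected step of a number 4.8 percentage points lower from compound 2 to compound 3 (within the scatter).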

Compound 3, a percentage reported as activity, at one concentration (the size of the read-out at that concentration, not a potency): 85.7%
Beside the measured number, compound 3's estimate is 4.3 percentage points above it; the range from low to high includes it.
By their numbers in this assay, from the lowest: compounds 1, 3 and 2 (each within the scatter of the next).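

Among the compounds shown here, the methoxy in place of hydrogen on an aromatic carbon, ortho to a hydroxy group, gives the first step between compounds that differ in one place: in this assay, the step is a number 9.1 percentage points lower from compound 2 to compound 3 (within the scatter). On this single step, the open-chain diol takes the 2 heavy atoms of methoxy, with its 1 hydrogen-bond acceptor, at this position without a reading that can be told apart from that of compound 2. No measurement at hand bears on what lies behind this result.

As far as these compounds go, it remains open whether a different group at this position, such as an amine, a carboxylic acid or a longer alkoxy chain like butoxy, would give a step beyond the scatter in this assay. One step also cannot show whether methoxy on the other aromatic ring of compound 2 would read the same, or whether the hydroxy group ortho to the methoxy has any bearing on the reading.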